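Trimming the aminobenzyl arm to a short ethoxy group

This account rests on a few compounds, and the source may have more. Where it says the series, first, only, none or still open, it means among the compounds named here.

Compound 1 `c1ccc(COc2ccc(OCCOCCNc3ccncc3)cc2)cc1` gives 20600 nM in a functional assay on SK-OV-3 cells (Homo sapiens) for inhibition, read by CCK-8 assay, with a stated time of 70 h; on this read-out higher numbers stand for weaker inhibition and lower numbers for stronger inhibition.
Compound 2 `Nc1ccc(COc2ccc(OCCOCCNC3CCCC3)cc2)cc1` gives 31700 nM in this assay.
Compound 3 `c1ccc(COc2ccc(COc3ccc(OCCOCCNC4CCCC4)cc3)cc2)cc1` gives 10000 nM in this assay.

Compound 2 has the highest number of the three; compound 1 lies within the scatter of it, while compound 3 sits beyond the scatter. Within the data shown here, the one shared-step comparison runs a 3.2-fold lower number from compound 2 to compound 3 (0.50 log units; beyond the scatter), where a benzyloxy group replaces the amino group on the aromatic carbon. Compound 4 `CCOc1ccc(OCCOCCNC2CCCC2)cc1` goes the other way: methyl in place of 4-aminophenyl on a saturated chain carbon bound to an oxygen on an aromatic ring. Among the measured compounds shown here, no measured step removes the aromatic arm in this manner, so the only guide is that compound 3, the largest of the three, has the lowest number. The estimate for compound 4 is therefore 40000 nM with a range of 15000 nM to 110000 nM, a step of a 1.3-fold higher number from compound 2 to compound 4 (0.10 log units; within the scatter) expected to stay within the scatter, if anything toward a higher number.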

Compound 4, half-maximal inhibitory concentration: 90500 nM
The estimate for compound 4 lay 2.3-fold (0.35 log units) below the measured number, within the range that was stated.
By their numbers in this assay, from the lowest: compound 3; then compounds 1 and 2 (each within the scatter of the next); then compound 4.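

Removing the aromatic ring from the arm, rather than only changing the group on it, moves the number upward, with a 2.9-fold higher number from compound 2 to compound 4 (0.46 log units; beyond the scatter). Compound 3 had shown a move the other way at the far end of this arm, with a 3.2-fold lower number from compound 2 to compound 3 (0.50 log units; beyond the scatter), so the arm responds in both directions, and its 4-aminophenyl part cannot be swapped for methyl without loss in this assay. No measurement here explains this loss.

The compounds shown leave open how an unsubstituted benzyl arm would read on this core, which would separate the ring from its amino group. A propyl or butyl arm would show whether the number changes gradually with chain length.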